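Para Isopropyl in Place of Meta Dimethylamino on the Amide

The source may report more compounds than this note shows. Statements on the series, on what has been measured and on what is new or still open speak of the compounds shown alone.

In an assay on HEK293 cells for antagonist activity at P2X purinoceptor 7 (Homo sapiens), read by fluorescence, with a stated time of 2 h (a higher number here means a weaker inhibitor, a lower number a stronger inhibitor), compound 3 `CN(C)c1cccc(C(=O)N2CCC(n3cncc3-c3ccc(OS(=O)(=O)c4cccc5cnccc45)cc3)CC2)c1` gives 155 nM, the second highest of the three numbers; compound 1 `O=C(c1ccc(Oc2ccccc2)cc1)N1CCC(n2cncc2-c2ccc(OS(=O)(=O)c3cccc4cnccc34)cc2)CC1` gives 187 nM, within the scatter of it, while compound 2 `CN(C)c1ccc(C(=O)N2CCC(n3cncc3-c3ccc(OS(=O)(=O)c4cccc5cnccc45)cc3)CC2)cc1` gives 0.11 nM. Compound 4 `CC(C)c1ccc(C(=O)N2CCC(n3cncc3-c3ccc(OS(=O)(=O)c4cccc5cnccc45)cc3)CC2)cc1` differs by 4-isopropylphenyl in place of 3-(dimethylamino)phenyl on a carbonyl carbon. Among the measured compounds shown here, two steps bear on this. The shift a 1400-fold higher number from compound 2 to compound 3 (3.15 log units; beyond the scatter) shows how much the dimethylamino position mattered, and a 1700-fold lower number from compound 1 to compound 2 (3.23 log units; beyond the scatter) shows that a 4-substituted ring is not potent on its own. Compound 4 carries its group on the favourable ring position but loses the acceptor, so a moderate step is expected, a 5.2-fold lower number from compound 3 to compound 4 (0.71 log units; beyond the scatter). The estimate for compound 4 in this assay is 30 nM, in the range 1 nM to 300 nM.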

Compound 4, half-maximal inhibitory concentration: 55 nM
The estimate for compound 4 lay 1.8-fold (0.26 log units) below the measured number; low and high end bracket the measured number.
By their numbers in this assay, from the lowest: compound 2; then compound 4; then compounds 3 and 1 (each within the scatter of the next).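

Replacing 3-(dimethylamino)phenyl with 4-isopropylphenyl gives a modest gain (a 2.8-fold lower number from compound 3 to compound 4 (0.45 log units; beyond the scatter)). Replacing dimethylamino with isopropyl on the same ring costs far more (a 500-fold higher number from compound 2 to compound 4 (2.70 log units; beyond the scatter)), whereas replacing phenoxy with isopropyl gives only a modest gain (a 3.4-fold lower number from compound 1 to compound 4 (0.53 log units; beyond the scatter)), so among these compounds only the dimethylamino group of compound 2 reaches a sub-nanomolar number. No measurement here explains the differences between these groups.

On these data alone, whether another amine in that place, such as diethylamino or pyrrolidinyl, would keep a number close to that of compound 2 remains open.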